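Working notes: from compound 2 to compound 4

This account rests on a few compounds, and the source may have more. Where it says the series, first, only, none or still open, it means among the compounds named here.

Compound 1 `O=C(Oc1ccc(Cl)cc1C(=O)Nc1ccc(Cl)c(Cl)c1)c1ccc(Br)cc1` gives > 50000 nM
Compound 2 `Cc1ccc(C(=O)Oc2ccc(Cl)cc2C(=O)Nc2ccc(Cl)c(Cl)c2)cc1` gives > 50000 nM
Compound 3 `Cc1ccc(C(=O)Oc2ccc(Cl)cc2C(=O)Nc2ccc(C(F)(F)F)cc2)cc1` gives > 50000 nM

In an ADME assay on HepG2 cells (Homo sapiens) for cytotoxicity, read by MTT assay, with a stated time of 72 h (on this read-out higher numbers stand for weaker inhibition and lower numbers for stronger inhibition), compound 2 gives > 50000 nM as a limit and not a number, so it has no exact standing in the series. The whole set so far offers only the limit of > 50000 nM in this assay, at which 3 of the 3 values shown sit, as its reading.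

The counted change nitro in place of methyl on an aromatic carbon takes compound 2 to compound 4 `O=C(Oc1ccc(Cl)cc1C(=O)Nc1ccc(Cl)c(Cl)c1)c1ccc([N+](=O)[O-])cc1` with nitro in place of methyl on an aromatic carbon, para to a large group.

Going by the values given here, two measured steps bear on this. The closer is a step that the two limits leave unreadable from compound 1 to compound 2 (methyl in place of bromo on an aromatic carbon). The other is a step that the two limits leave unreadable from compound 2 to compound 3 (4-(trifluoromethyl)phenyl in place of 3,4-dichlorophenyl on an amide-type nitrogen). Neither has a readable size and neither gives a direction. With only these to go on, no step beyond the scatter is expected in this assay and no direction is assigned, though the data cannot exclude one. The estimate amounts to a number no higher from compound 2 to compound 4 (the limit leaves the size open) as the expected step. For compound 4 the estimated value is 50000 nM with an expected range from 20000 nM to 100000 nM and a report as a limit again is the likeliest outcome.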

Compound 4, half-maximal inhibitory concentration: > 50000 nM
Compound 4 was reported as a limit; the forecaster's own chance of this, stated with the estimate: 80%; the middle value sits exactly at the limit.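

In this assay compound 4 gives > 50000 nM, a limit and not a number. The steps joining compound 4 to compound 1 and compound 2 cannot be read, so no new step comes from this result: the limit of > 50000 nM in this assay, at which 4 of the 4 values shown sit.

The compounds shown leave open whether any of these changes moves the read-out in this assay, and in which direction.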